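Methylsulfonyl to chloro on the shared core

The compounds below may be only part of what the source reports. "The series", "measured", "known", "first", "only" and "open" are said of these compounds alone.

Two compounds carry numbers in a functional assay on HeLa cells (Homo sapiens) for inhibition, read by MTT assay, with a stated time of 48 h; a higher number here means a weaker inhibitor, a lower number a stronger inhibitor. Compound 1 `CS(=O)(=O)c1ccc(-c2nc3ccccn3c2Sc2ccccc2)cc1` gives 70600 nM and stands as the higher of the two numbers. Compound 2 `CSc1ccc(-c2nc3ccccn3c2Sc2ccccc2)cc1` gives 30000 nM, the nearer and lower one. Within the data shown here, the only step between measured compounds, a 2.4-fold lower number from compound 1 to compound 2 (0.37 log units; beyond the scatter), comes from methylsulfanyl in place of methylsulfonyl on an aromatic carbon, a modest change that lies beyond the scatter.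

Compound 3 `Clc1ccc(-c2nc3ccccn3c2Sc2ccccc2)cc1` remains to be measured. Against compound 1 it shows (chloro in place of methylsulfonyl on an aromatic carbon). The leaving group is the same methylsulfonyl as in the step to compound 2, and the entering chloro, like methylsulfanyl, brings no hydrogen-bond acceptor, so that single step is the one that bears on this change. A lower number is therefore expected, of a size comparable to that step; nothing in the two measured compounds supports a larger or an opposite move.

Compound 3 is expected to give about 25000 nM in this assay, within 8000 nM to 70000 nM. The estimated step is a 2.8-fold lower number from compound 1 to compound 3 (0.45 log units; beyond the scatter).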

Compound 3, half-maximal inhibitory concentration: 62000 nM
Compound 3: middle estimate off by 2.5-fold (0.39 log units), on the low side; the range from low to high includes it.
By their numbers in this assay, from the lowest: compound 2; then compounds 3 and 1 (each within the scatter of the next).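

At this position, on an aromatic carbon para to a large group, chloro in place of methylsulfonyl gives a 1.1-fold lower number from compound 1 to compound 3 (0.06 log units; within the scatter) in this assay, so this replacement leaves the two compounds indistinguishable even though methylsulfonyl carries hydrogen-bond acceptors and chloro carries none. Replacing methylsulfonyl therefore does not in itself account for the step to compound 2, and the comparison between the two entering groups gives a 2.1-fold higher number from compound 2 to compound 3 (0.32 log units; beyond the scatter) as a modest separation. Of the three compounds, compound 2, with methylsulfanyl, is the only one set apart beyond the scatter from both others, which makes the effect look specific to that group on this small set, not general to the removal of methylsulfonyl.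

No data here explain why methylsulfanyl stands apart from chloro. The compounds shown leave open whether a methoxy group, an amine, a carboxylic acid or a longer sulfur-linked chain such as ethylsulfanyl at the same position would follow methylsulfanyl or chloro, and all three numbers remain within a narrow band, so the series does not yet show how far this position can move the value.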